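A Methyl Step Repeated on a Second Core

A few compounds are considered here, and "the series" means these few. Any claim that something is new, unique, unknown or untested is made for them only; others in the source may bear on it.

Measured compounds:
Compound 1 `O=C(Nc1cnn(-c2ccccc2)c1)c1cccc(NS(=O)(=O)c2ccc(Cl)cc2)c1` gives 8540 nM in a functional assay on HepG2 cells (Homo sapiens) for inhibition, read by MTT assay, with a stated time of 48 h; on this read-out lower numbers stand for stronger inhibition and higher numbers for weaker inhibition.
Compound 2 `Cc1ccc(-n2cc(NC(=O)c3cccc(NS(=O)(=O)c4ccc(Cl)cc4)c3)cn2)cc1` gives 2440 nM in this assay.
Compound 3 `O=C(Nc1cnn(-c2ccccc2)c1)c1ccc(NS(=O)(=O)c2ccccc2)cc1` gives 21500 nM in this assay.

Compound 1 and compound 2 differ in one place only, (methyl in place of hydrogen on an aromatic carbon), and that change brought a 3.5-fold lower number from compound 1 to compound 2 (0.54 log units; beyond the scatter). Compound 3 has the highest number of the three measured compounds in this assay.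

Compound 4 `Cc1ccc(-n2cc(NC(=O)c3ccc(NS(=O)(=O)c4ccccc4)cc3)cn2)cc1` is not yet measured. It differs from compound 3 by the same change, (methyl in place of hydrogen on an aromatic carbon), at the same kind of place. The difference between the core of compound 1 and the core of compound 3 is not broken down here.

Among the compounds with values here, because the step of a 3.5-fold lower number from compound 1 to compound 2 (0.54 log units; beyond the scatter) was clear and beyond the scatter, a similar step is expected when the same change is made on the core of compound 3, though with only one earlier example its size is uncertain. The expected step is a 3.1-fold lower number from compound 3 to compound 4 (0.49 log units; beyond the scatter). Compound 4 is therefore estimated at 7000 nM in this assay, with a likely range from 3000 nM to 18000 nM.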

Compound 4, half-maximal inhibitory concentration: 18100 nM
Compound 4: middle estimate off by 2.6-fold (0.41 log units), on the low side, and the stated range ends below it.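

On the second core, the change from phenyl to 4-methylphenyl brought a 1.2-fold lower number from compound 3 to compound 4 (0.07 log units; within the scatter) in this assay and so made no difference that can be read here. The gain seen on the first core therefore did not carry over in the same size, and the two steps truly differ: the same change on two cores in this assay, a 3.5-fold lower number (0.54 log units; beyond the scatter) from compound 1 to compound 2 and a 1.2-fold lower number (0.07 log units; within the scatter) from compound 3 to compound 4, 2.9-fold (0.47 log units) apart, beyond the scatter of two such steps.

Within the data shown here, this shows that, in this series, the effect of the methyl depends on the core it is placed on, but it does not show which feature of the cores is responsible, since the difference between them is not broken down and each core offers only one step.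

As far as these compounds go, it remains open whether a different group at the same place, such as an ethyl group, a methoxy group or an amine, would also act differently on the two cores. From the compounds shown here alone, it is also open whether the methyl step would hold on any further core, or whether it would look more like the first step or the second.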